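Isobutyl carbamate selenocyanate, a close relative of compound 3

The source may report more compounds than this note shows. Statements on the series, on what has been measured and on what is new or still open speak of the compounds shown alone.

Three carbamate-bearing selenium compounds have numbers in a functional assay on HT-29 cells (Homo sapiens) for cytotoxicity, read by MTT assay, with a stated time of 72 h; a higher number here means a weaker inhibitor of growth, a lower number a stronger inhibitor of growth. Compound 1 `CC(C)COC(=O)Nc1ccc([Se][Se]c2ccc(NC(=O)OCC(C)C)cc2)cc1`, a diselenide with isobutyl carbamates on both arms, gives 19900 nM. Compound 2 `N#C[Se]c1ccc(NC(=O)Oc2ccc(F)cc2)cc1`, a selenocyanate carrying an aryl carbamate, gives 8800 nM. Compound 3 `C=CCOC(=O)Nc1ccc([Se]C#N)cc1`, the allyl carbamate selenocyanate, gives 24500 nM; this is the highest of the three numbers, within the scatter of compound 1 and beyond the scatter of compound 2.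

Compound 4 `CC(C)COC(=O)Nc1ccc([Se]C#N)cc1` has not yet been measured in this assay. It differs from compound 3 in one place: isopropyl in place of vinyl on a saturated chain carbon bound to an oxygen next to a carbonyl group. This leaves the selenocyanate and the carbamate unchanged and only replaces one small alkyl chain on the carbamate oxygen by another.

Going by the values given here, no measured pair isolates this chain change, so its effect is unknown. Compound 1, the only other isobutyl carbamate here, gives 19900 nM, a number within the scatter of compound 3. A step of no size beyond the scatter is therefore expected, a 1.2-fold lower number from compound 3 to compound 4 (0.09 log units; within the scatter). For compound 4 in this assay the estimate is 20000 nM, with a range from 8000 nM to 50000 nM.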

Compound 4, concentration for 50% growth inhibition: 8100 nM
Compound 4: the middle estimate sits 2.5-fold (0.39 log units) above what was measured; measured number inside the range.
By their numbers in this assay, from the lowest: compounds 4 and 2 (each within the scatter of the next); then compounds 1 and 3 (each within the scatter of the next).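

In this assay the chain on the carbamate oxygen turns out to matter: the series shows a 3.0-fold lower number from compound 3 to compound 4 (0.48 log units; beyond the scatter) with the selenocyanate and the carbamate unchanged. Going by these compounds alone, this is the first step that isolates this place, and exchanging allyl for isobutyl moves the number beyond the scatter, though only modestly. Nothing available explains the size or direction of this step.

From the compounds shown here alone, whether the step follows the loss of the double bond outside aromatic rings or the arrival of the branched isopropyl end remains open, and a straight propyl chain on the carbamate oxygen would separate the two. Also open, going by these compounds, is how the selenocyanate series responds to a longer chain such as hexyl, or to a chain ending in an amine or a carboxylic acid.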